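Pyridinylmethylamino Replacing Methyl on a Thienopyrimidine Ketone Core

This account rests on a few compounds, and the source may have more. Where it says the series, first, only, none or still open, it means among the compounds named here.

Compound 1 `Cc1nc(C(=O)c2ccc(C)s2)c2sccc2n1`: > 10000 nM
Compound 2 `CCNc1nc(C(=O)c2ccc(C)s2)c2sccc2n1`: 1260 nM

In a functional assay on CHO-K1 cells for antagonist activity at adenosine receptor A2b (Homo sapiens), read by FLIPR and calcium flux (a lower number here means a stronger inhibitor, a higher number a weaker inhibitor), compound 1 gives > 10000 nM, which is a limit of the assay and not a number. For compound 2 this assay gives 1260 nM. Among the compounds with values here, the one measured step, an at least 7.9-fold lower number from compound 1 to compound 2 (0.89 log units; beyond the scatter), is a lower bound because compound 1 sits at the limit of > 10000 nM in this assay, at which 1 of the 2 values shown sits. Compound 3 `Cc1ccc(C(=O)c2nc(NCc3ccccn3)nc3ccsc23)s1` departs from compound 1 by ((pyridin-2-yl)methyl)amino in place of methyl on an aromatic carbon. This change resembles the ethylamino step, so a drop of similar or larger size is expected, an at least 16-fold lower number from compound 1 to compound 3 (1.22 log units; beyond the scatter). Compound 3 is therefore estimated at 600 nM, between 150 nM and 3000 nM.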

Compound 3, half-maximal inhibitory concentration: 43 nM
Compound 3: middle estimate off by 14-fold (1.14 log units), on the high side; measured number outside the range, below it.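

In this assay, the ethylamino step alone did not show how much the end of the chain on this carbon between two ring nitrogen atoms could matter. With the amino link kept, pyridin-2-yl in place of methyl on the chain gives a 29-fold lower number from compound 2 to compound 3 (1.47 log units; beyond the scatter), so the amino link alone does not account for the result of compound 3. The full change from methyl gives an at least 230-fold lower number from compound 1 to compound 3 (2.36 log units; beyond the scatter), and this is only a lower bound because compound 1 stands at a limit: the limit of > 10000 nM in this assay, at which 1 of the 3 values shown sits.

The compounds shown leave open whether the ring nitrogen of the pyridin-2-yl group counts, which a benzylamino or (pyridin-4-yl)methylamino group would test. They also leave open whether a longer chain carrying the same ring would keep the gain.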